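Removing the nitro group: compound 3 to compound 4

This account rests on a few compounds, and the source may have more. Where it says the series, first, only, none or still open, it means among the compounds named here.

Compound 3 `Cn1nnnc1SCC(=O)N/N=c1/scc(-c2ccc([N+](=O)[O-])cc2)n1-c1ccccc1` reaches only the upper limit of a functional assay on C6 cells (Rattus norvegicus) for cytotoxicity, read by MTT assay, with a stated time of 24 h (on this read-out higher numbers stand for weaker inhibition and lower numbers for stronger inhibition), reading > 200 ug/mL; the assay gives no single number for it. Its cyano counterpart, compound 2 `Cn1nnnc1SCC(=O)N/N=c1/scc(-c2ccc(C#N)cc2)n1-c1ccccc1`, gives 23.3 ug/mL in this assay. For compound 1 `O=C(CSc1ncccn1)N/N=c1/scc(-c2ccccc2)n1-c1ccccc1` the entry in this assay reads "not determined" (no result reported). Among the compounds with values here, the only measured step that bears on the change is an at least 8.5-fold higher number from compound 2 to compound 3 (0.93 log units; beyond the scatter), where a single aromatic substituent swings the read-out to the limit (the limit of > 200 ug/mL in this assay, at which 1 of the 3 values shown sits). Compound 4 `Cn1nnnc1SCC(=O)N/N=c1/scc(-c2ccccc2)n1-c1ccccc1` differs from compound 3 by hydrogen in place of nitro on an aromatic carbon. Within the data shown here, because compound 3 sits at the limit and only one step, an at least 8.5-fold higher number from compound 2 to compound 3 (0.93 log units; beyond the scatter), informs the change, a lower number is expected, an at least 2.8-fold lower number from compound 3 to compound 4 (0.45 log units; beyond the scatter), though with wide uncertainty. Compound 4 is therefore estimated at 70 ug/mL, between 15 ug/mL and 200 ug/mL.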

Compound 4, half-maximal inhibitory concentration: 67.7 ug/mL
Estimate against measurement, compound 4: 1.0-fold (0.01 log units) above, within the range that was stated.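

In this assay, the unsubstituted phenyl ring provides a reference for this position, with an at least 2.9-fold lower number from compound 3 to compound 4 (0.47 log units; beyond the scatter) and a 2.9-fold higher number from compound 2 to compound 4 (0.46 log units; beyond the scatter). Relative to hydrogen, nitro and nitrile therefore move the read-out in opposite directions, which the comparison of those two groups alone could not show. The value for compound 3 remains a limit of the assay, so the full size of the nitro step stays unknown: the limit of > 200 ug/mL in this assay, at which 1 of the 4 values shown sits.

Still open, from the compounds shown here alone, is where an amine, a carboxylic acid or a methoxy group at this position would fall relative to hydrogen. Three substituents establish no trend.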